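Hydrogen for fluoro: expected half-life of compound 3

The source may hold more compounds than are shown below. What is called first, only, known or untested is meant among the compounds shown, and "the series" means these compounds.

Two compounds of the series carry a number in an in vitro ADME assay on microsomes from liver (Homo sapiens) for metabolic stability; a higher number here means that the compound lasts longer, a lower number that the compound disappears faster. Compound 1 `Nc1nccc(-c2ccc3nc(C4COc5ccc(F)cc5C4)oc3c2)n1` gives 1.52 h, the higher of the two. For the measured compounds named here, compound 2 `c1ccc2c(c1)CC(c1nc3ccc(-c4cn[nH]c4)cc3[nH]1)CO2` gives 0.333 h in this assay, a lower value, and the gap between the two lies beyond the usual scatter; compound 2 differs from compound 1 in more than one place, so the pair yields no single step and the two values are simply noted side by side.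

Compound 3 `Nc1nccc(-c2ccc3nc(C4COc5ccccc5C4)oc3c2)n1` has not yet been measured. It differs from compound 1 in one place: hydrogen in place of fluoro on an aromatic carbon of a six-membered aromatic ring of carbon only, part of a fused system of two rings, meta to a fused ring and para to a fused ring. Going by the values given here, no measured pair shows this change, so nothing fixes its size. The expectation for this assay is a step of a 1.7-fold lower number from compound 1 to compound 3 (0.23 log units; within the scatter), a moderate decrease rather than a change within the scatter. For compound 3 the estimate in this assay is 0.9 h, with a range from 0.4 h to 1.8 h.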

Compound 3, half-life: 0.95 h
Compound 3: middle estimate off by 1.1-fold (0.02 log units), on the low side; measured number inside the range.
By their numbers in this assay, from the lowest: compound 2; then compounds 3 and 1 (each within the scatter of the next).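

In this assay, hydrogen in place of fluoro on an aromatic carbon (a 1.6-fold lower number from compound 1 to compound 3 (0.20 log units; within the scatter)) gives the series its first step that can be read at a single place, and that step stays within the scatter. At this carbon of the six-membered aromatic ring of carbon only, meta to a fused ring and para to a fused ring, half-life therefore does not separate fluoro from hydrogen, a reading that rests on this one pair on the core of compound 1. No supporting data are available that bear on the size of this step.

Whether a larger or differently built substituent at this carbon, such as chloro, methoxy, trifluoromethyl or a nitrile, would give a step beyond the scatter remains open, since fluoro and hydrogen are the only two groups shown here. Also open, going by these compounds, is whether fluoro in place of hydrogen on another aromatic carbon of the same ring, or the same change on a different core, would give a step of similar size.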